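The compounds below may be only part of what the source reports. "The series", "measured", "known", "first", "only" and "open" are said of these compounds alone.

In a functional assay on HL-60 cells (Homo sapiens) for cytotoxicity, read by WST assay, with a stated time of 48 h (a higher number here means that more compound is needed for the effect, a lower number that less compound is needed), compound 1 (`O=C1OC[C@H](Cc2ccccc2)[C@H]1Cc1ccccc1C(F)(F)F`) gives 37000 nM and compound 2 (`COc1ccc(C[C@H]2C(=O)OC[C@@H]2Cc2ccccc2)cc1`) gives 67000 nM, so these two values lie within the usual scatter of each other. Compound 3 (`CCCCCCCOc1ccc(C[C@H]2C(=O)OC[C@@H]2Cc2ccccc2)cc1`) differs from compound 2 by hexyl in place of hydrogen on a saturated chain carbon bound to an oxygen on an aromatic ring, which turns methoxy into heptyloxy. For the measured compounds named here, no measured step shows what such a change does in this assay. A moderate move towards a lower number is nevertheless expected, with an estimated step of a 4.5-fold lower number from compound 2 to compound 3 (0.65 log units; beyond the scatter). For compound 3 the estimated value is 15000 nM, with an expected range from 4000 nM to 60000 nM.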

Compound 3, half-maximal effective concentration: > 100000 nM
Compound 3 was reported as a limit; the forecaster's own chance of this, stated with the estimate: 10%; at least 6.6-fold (0.82 log units) between middle value and limit.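

In this assay, compound 3 is reported only as a limit, not as a number: the limit of > 100000 nM in this assay, at which 1 of the 3 values shown sits.

The change from methoxy to heptyloxy gives an at least 1.4-fold higher number from compound 2 to compound 3 (0.17 log units; that floor lies within the scatter), so this longer chain on the oxygen brings no move towards a lower number. Whether the number truly rises cannot be told from that floor, which lies within the scatter.

The compounds shown leave open how a chain of intermediate length, such as butoxy, would read here. They also leave open whether an amine or a carboxylic acid in place of the heptyloxy would give a lower number.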